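The source may report more compounds than this note shows. Statements on the series, on what has been measured and on what is new or still open speak of the compounds shown alone.

Of the compounds shown here, two built on a shared core have so far been measured in a physicochemical assay for lipophilicity, read by mass spectrometry; a higher number here means a more lipophilic compound, a lower number a more polar compound. Compound 1 (`CCc1cccc(NC(=O)C2Cc3cc(OC)c(OC)cc3C2=O)c1`) gives 3.11, and compound 2 (`CCOc1ccccc1NC(=O)C1Cc2cc(OC)c(OC)cc2C1=O`) gives 2.42. Compound 2 therefore holds the lower of the two numbers, and its gap to compound 1 lies beyond the usual scatter of such measurements.

The next compound, compound 3 (`COc1cc2c(cc1OC)C(=O)C(C(=O)Nc1ccccc1F)C2`), differs from compound 2 in one place, with fluoro in place of ethoxy on an aromatic carbon, ortho to a large group: fluoro in place of ethoxy on an aromatic carbon. Going by the values given here, no measured pair shows this exchange, so nothing in the data gives its size directly. The expectation starts from compound 2 at 2.42 and from the structural change alone, and it remains uncertain. A modest fall in this assay is expected, with an estimated step of a number 0.22 log units lower from compound 2 to compound 3 (within the scatter), a size that may not clear the scatter. For compound 3 the estimated value is 2.2, with an expected range from 1.8 to 2.7.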

Compound 3, partition coefficient: 2.36
Compound 3: middle estimate off by 0.16 log units, on the low side, within the range that was stated.
By their numbers in this assay, from the lowest: compounds 3 and 2 (each within the scatter of the next); then compound 1.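

In this assay, fluoro in place of ethoxy on an aromatic carbon, ortho to a large group, gives a number 0.06 log units lower from compound 2 to compound 3 (within the scatter), so at this position the exchange of 3 heavy atoms for 1 heavy atom cannot be read as a real difference in this measure. The step of 2-fluorophenyl in place of 3-ethylphenyl on an amide-type nitrogen is of another order, at a number 0.75 log units lower from compound 1 to compound 3 (beyond the scatter), and it shows that the gap to compound 1 seen with ethoxy persists with fluoro. Nothing available bears on the reason for either step.

The step from compound 1 to compound 3 alters both the group on the aromatic ring and its place, so these compounds cannot divide the difference between those two changes. Going by these compounds, it also remains open whether the same position would give a similar number with a different kind of group, such as an amine, a carboxylic acid or a longer chain than ethoxy.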